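Replacing Methylsulfanyl on the Saturated Ring Carbon

The compounds below may be only part of what the source reports. "The series", "measured", "known", "first", "only" and "open" are said of these compounds alone.

Going by the values given here, compound 2 `CSC1(c2cc(F)cc(OCc3ccc(-n4ccnc4C)cc3)c2)CCOCC1` gives 72 nM in an assay on blood for inhibition of Polyunsaturated fatty acid 5-lipoxygenase (Homo sapiens) (on this read-out lower numbers stand for stronger inhibition and higher numbers for weaker inhibition), the lowest of the two numbers measured so far. Its nearest neighbour is compound 1 `CCOC(=O)C1(c2cc(F)cc(OCc3ccc(-n4ccnc4C)cc3)c2)CCOCC1`, which in this assay gives 200 nM. The two are separated by a 2.8-fold lower number from compound 1 to compound 2 (0.44 log units; beyond the scatter). Compound 3 `Cc1nccn1-c1ccc(COc2cc(F)cc(C3([S+](C)[O-])CCOCC3)c2)cc1` has not yet been measured. It differs from compound 2 by a group of 3 heavy atoms (1 carbon, 1 oxygen, 1 sulfur; no ring) in place of a group of 2 heavy atoms (1 carbon, 1 sulfur; no ring), on a saturated ring carbon. Among the compounds with values here, the only measured step, a 2.8-fold lower number from compound 1 to compound 2 (0.44 log units; beyond the scatter), concerns a different exchange at the same saturated ring carbon and shows that this position accepts change in a modest way, but the group that enters compound 3 takes part in no measured step. Within the data shown here, no measured step therefore bears directly on the change from compound 2 to compound 3. Compound 3 is expected to give 150 nM in this assay, with a range of 50 nM to 450 nM. The expected step of a 2.1-fold higher number from compound 2 to compound 3 (0.32 log units; beyond the scatter) is estimated as a modest weakening, barely beyond the scatter.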

Compound 3, half-maximal inhibitory concentration: > 1000 nM
Compound 3: no number, only a limit; the forecaster's own chance of this, stated with the estimate: 5%; at least 6.6-fold (0.82 log units) between middle value and limit.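

In this assay compound 3 gives no number, only a limit of the assay: the limit of > 1000 nM in this assay, at which 1 of the 3 values shown sits. Going by these compounds alone, exchanging methylsulfanyl for the group of 3 heavy atoms (1 carbon, 1 oxygen, 1 sulfur) gives an at least 13-fold higher number from compound 2 to compound 3 (1.14 log units; beyond the scatter), a large step where the only earlier step at this saturated ring carbon was modest, so a small exchange here can weigh heavily. The same group also compares poorly with ethoxycarbonyl, with an at least 5.0-fold higher number from compound 1 to compound 3 (0.69 log units; beyond the scatter), which shows that this position does not accept every change.

On these data alone, the full size of both steps stays open, since one end of each is a limit. The compounds shown also leave open how an amine or a carboxylic acid would fare on this saturated ring carbon, and whether a longer chain such as ethylsulfanyl would keep the level of compound 2.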